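Moving the Bromine Within the Benzoate Ring

The compounds below may be only part of what the source reports. "The series", "measured", "known", "first", "only" and "open" are said of these compounds alone.

Three compounds sharing one core were tested in an ADME assay on cells (T-cell, Mus musculus, strain BALB/c) for cytotoxicity, read by MTT assay, with a stated time of 48 h; on this read-out higher numbers stand for lower toxicity in this test and lower numbers for higher toxicity in this test. Compound 1 `COC(=O)c1c(Cl)cc(Cl)cc1OC(=O)COc1cc(O)c2c(=O)cc(-c3ccccc3)oc2c1` gives 345000 nM, compound 2 `COC(=O)c1cccc(OC)c1OC(=O)COc1cc(O)c2c(=O)cc(-c3ccccc3)oc2c1` gives 196000 nM, and compound 3 `COC(=O)c1c(Br)cccc1OC(=O)COc1cc(O)c2c(=O)cc(-c3ccccc3)oc2c1` gives 388000 nM in this assay. Compound 3 holds the highest of the three numbers, yet the value of compound 1 and the value of compound 2 both lie within the usual scatter of its own, so no ranking of toxicity among the three can be drawn from these figures.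

Compound 4 `COC(=O)c1ccc(Br)cc1OC(=O)COc1cc(O)c2c(=O)cc(-c3ccccc3)oc2c1` has not yet been measured. It differs from compound 3 in the following way: a group of 11 heavy atoms (8 carbon, 2 oxygen, 1 bromine; one six-membered aromatic ring of carbon only) in place of a group of 11 heavy atoms (8 carbon, 2 oxygen, 1 bromine; one six-membered aromatic ring of carbon only), on an oxygen next to a carbonyl group. The two compounds have the same atoms joined differently, with the bromine placed elsewhere on the same aromatic ring of the ester portion.

Among the measured compounds shown here, no measured pair in this set isolates such a repositioning, so there is no direct precedent. Given that the three measured values in this assay all fall within the usual scatter of one another, the step from compound 3 to compound 4 is expected to be small, a 1.1-fold lower number from compound 3 to compound 4 (0.04 log units; within the scatter), with no clear direction beyond the scatter. Compound 4 is therefore estimated to give 350000 nM in this assay, with a range from 180000 nM to 650000 nM.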

Compound 4, half-maximal cytotoxic concentration: 326000 nM
Compound 4: the middle estimate sits 1.1-fold (0.03 log units) above what was measured; measured number inside the range.
By their numbers in this assay, from the lowest: compounds 2, 4, 1 and 3 (each within the scatter of the next).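

Among the compounds shown here, compound 3 and compound 4 form the first pair here that differs in one place only: in this assay the pair shows a 1.2-fold lower number from compound 3 to compound 4 (0.08 log units; within the scatter) when the bromine moves to another place on the aromatic ring of the ester portion, with the atoms otherwise unchanged. For the compounds shown here, for this pair, the place of the bromine on that ring therefore leaves the read-out within the usual scatter, which the earlier compounds, no two of which differ in one place, could not show. Nothing measured here bears on why the two numbers stay so close.

Only these two placements of bromine on this ring are shown, so it remains open whether an amine on the ring, or a carboxylic acid in place of the ester, would move the number beyond the scatter. As far as these compounds go, whether moving a chlorine would give an equally small step is also open.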